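The source may report more compounds than this note shows. Statements on the series, on what has been measured and on what is new or still open speak of the compounds shown alone.

Measured compounds:
compound 1 `FC(F)(F)Oc1ccc(-c2cc(COc3ccccc3-c3nc4ccccc4s3)on2)cc1` — 19900 nM
compound 2 `FC(F)(F)c1cccc(-n2cc(COc3ccccc3-c3nc4ccccc4s3)nn2)c1` — 10800 nM
compound 3 `COc1cc(-c2cc(COc3ccccc3-c3nc4ccccc4s3)on2)cc(OC)c1OC` — 17500 nM

Of the compounds shown here, three have been tested in a functional assay on COLO 205 cells (Homo sapiens) for cytotoxicity, read by MTT assay, with a stated time of 24 h; a higher number here means a weaker inhibitor, a lower number a stronger inhibitor. Compound 1 gives 19900 nM. Compound 3 gives 17500 nM in this assay, and compound 2 gives 10800 nM. All three numbers lie within the usual scatter of one another, so none of the three can be set apart as a stronger or weaker inhibitor on these data; compound 1 sits among them without a gap to either neighbour that the assay could resolve. Among the measured compounds shown here, no step between two measured compounds that differ in only one place is available, so there is no measured pair from which to read how a single change moves the number.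

The next compound, compound 4 `Fc1ccccc1-c1cc(COc2ccccc2-c2nc3ccccc3s2)on1`, differs from compound 1 in one place: 2-fluorophenyl in place of 4-(trifluoromethoxy)phenyl on an aromatic carbon. Because the three measured values of compound 1, compound 2 and compound 3 all sit in the same narrow band, the step from compound 1 to compound 4 is expected to be small, in either direction, and probably not beyond the scatter, at a 1.3-fold lower number from compound 1 to compound 4 (0.12 log units; within the scatter). Compound 4 is therefore estimated to give 15000 nM in this assay, with an expected range from 5000 nM to 45000 nM.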

Compound 4, half-maximal inhibitory concentration: 18300 nM
Compound 4: the middle estimate sits 1.2-fold (0.09 log units) below what was measured, within the range that was stated.
By their numbers in this assay, from the lowest: compounds 2, 3, 4 and 1 (each within the scatter of the next).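

In this assay, among the compounds shown here, the exchange of 4-(trifluoromethoxy)phenyl for 2-fluorophenyl, on the aromatic carbon next to the ring nitrogen of the five-membered aromatic ring, gives a 1.1-fold lower number from compound 1 to compound 4 (0.04 log units; within the scatter) and so provides the first measured pair that differs in only one place. The two groups are not alike by simple counts, with 11 heavy atoms and 1 hydrogen-bond acceptor leaving and 7 heavy atoms and 0 hydrogen-bond acceptors entering, yet the assay cannot tell compound 1 and compound 4 apart, so at this position this particular change leaves no resolvable mark on the number. No separate measurement offers any explanation for this result.

As far as these compounds go, both groups compared here are substituted phenyl rings, so it remains open whether a group of a different kind at this position, such as an amine, a carboxylic acid or a longer alkyl chain, would move the number beyond the scatter. Also open, from the compounds shown here alone, is whether unsubstituted phenyl, or 4-fluorophenyl, would behave any differently from the two groups seen here.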